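Arylamine ring changes across the shared core

This account rests on a few compounds, and the source may have more. Where it says the series, first, only, none or still open, it means among the compounds named here.

Compound 1 `Cc1ccc(NC2=CC(=O)c3c(nc4n3[C@H]3OC[C@@H](O)[C@H]3OC4)C2=O)cc1C` gives 4090 nM in a functional assay on ECa-109 cells for inhibition, with ECa-109 cell line (Homo sapiens) as the target, read by sulforhodamine B assay; a lower number here means a stronger inhibitor, a higher number a weaker inhibitor. Compound 2 `CCc1ccc(NC2=CC(=O)c3nc4n(c3C2=O)[C@H]2OC[C@@H](O)[C@H]2OC4)cc1` gives 3080 nM in this assay, and the two numbers lie within the usual scatter of each other, so no order between compound 1 and compound 2 can be read from them. Compound 3 `O=C1C=C(N2CCCCC2)C(=O)c2c1nc1n2[C@H]2OC[C@@H](O)[C@H]2OC1` reaches only a limit of this assay, > 8000 nM. For the measured compounds named here, the single counted step, an at least 2.5-fold higher number from compound 2 to compound 3 (0.41 log units; beyond the scatter), ends at this limit of > 8000 nM in this assay, at which 1 of the 3 values shown sits, and replaces the whole arylamine with piperidin-1-yl; it does not bear directly on compound 4, where the arylamine is kept. Compound 4 `O=C1C(Nc2cccc(F)c2)=CC(=O)c2c1nc1n2[C@H]2OC[C@@H](O)[C@H]2OC1` differs from compound 1 by 3-fluorophenyl in place of 3,4-dimethylphenyl on an amine nitrogen. Going by the values given here, the only comparable pair, compound 1 against compound 2, shows that exchanging one substituted aryl ring for another left the number within the scatter. For compound 4 no step beyond the scatter is therefore expected, a 1.1-fold lower number from compound 1 to compound 4 (0.06 log units; within the scatter). Compound 4 is estimated at 3600 nM, between 1500 nM and 8000 nM.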

Compound 4, half-maximal inhibitory concentration: 2370 nM
Beside the measured number, compound 4's estimate is 1.5-fold (0.18 log units) above it; measured number inside the range.
By their numbers in this assay, from the lowest: compounds 4, 2 and 1 (each within the scatter of the next). At a limit, above all of these: compound 3.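

The aryl ring at this amine nitrogen now carries a fluorine in place of the two methyl groups, and the alkyl substituents of compounds 1 and 2 turn out not to be needed to keep the number in this range: the change gives a 1.7-fold lower number from compound 1 to compound 4 (0.24 log units; within the scatter) and sets no order between the two compounds. Compounds 4, 2 and 1 therefore stand each within the scatter of the next, so three differently substituted phenyl rings on the amine nitrogen cannot be told apart in this assay. Nothing available speaks to any cause behind this small step.

Open, from the compounds shown here alone, is whether a methoxy group or a carboxylic acid on the phenyl ring would move the number beyond the scatter. A pyridine ring in place of the phenyl ring also remains to be seen.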